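Replacing a hydroxy group with a sulfonamide: tolerability outlook

The source may report more compounds than this note shows. Statements on the series, on what has been measured and on what is new or still open speak of the compounds shown alone.

Compound 1 `COc1ccc([C@H]2CC(=O)N(c3cccc(O)c3)C2)cc1OC1CCCC1` was tested in a functional assay on HEK293 cells (Homo sapiens) for cytotoxicity; a higher number here means that more compound is tolerated, a lower number that less compound is tolerated. In this assay compound 1 gives > 10000 nM, which is a limit of the assay and not a number. Compound 2 `COc1ccc([C@H]2CC(=O)N(c3ccccc3N)C2)cc1OC1CCCC1` carries 2-aminophenyl in place of 3-hydroxyphenyl on the amide-type nitrogen in the ring. In this assay compound 2 gives > 10000 nM, again a limit rather than a number. Compound 3 `COc1ccc([C@H]2CC(=O)N(c3ccncc3)C2)cc1OC1CCCC1` carries pyridin-4-yl on the amide-type nitrogen in the ring. In this assay compound 3 gives > 10000 nM, also a limit. The steps a step that the two limits leave unreadable from compound 1 to compound 2, a step that the two limits leave unreadable from compound 1 to compound 3 and a step that the two limits leave unreadable from compound 2 to compound 3 therefore cannot be sized, and all three values sit at the limit of > 10000 nM in this assay, at which 3 of the 3 values shown sit.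

Compound 4 `COc1ccc([C@H]2CC(=O)N(c3cccc(NS(=O)(=O)c4cccc(F)c4)c3)C2)cc1OC1CCCC1` differs from compound 1 by ((3-fluorophenyl)sulfonyl)amino in place of hydroxy on an aromatic carbon. Among the measured compounds shown here, none of the measured steps covers a change of this kind; they show only that the three groups seen on the amide-type nitrogen left tolerance at the limit. For the measured compounds named here, no step of readable size is therefore expected, and compound 4 is expected to sit near the same limit, with the step of a number no higher from compound 1 to compound 4 (the limit leaves the size open) expected to be small. For compound 4 the estimate is 10000 nM, with a range from 3000 nM to 30000 nM.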

Compound 4, half-maximal cytotoxic concentration: > 10000 nM
Compound 4 gave a limit, no number (the forecaster's own chance of this, stated with the estimate: 60%); the middle value lies on the limit itself.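

In this assay compound 4 gives > 10000 nM, which is a limit of the assay and not a number. The step from compound 1 to compound 4 therefore cannot be read, and all values remain at one limit: the limit of > 10000 nM in this assay, at which 4 of the 4 values shown sit.

The compounds shown leave open where the actual values of compounds 1, 2, 3 and 4 lie, and whether any change on the shared core would lower tolerance in this assay.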